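This account rests on a few compounds, and the source may have more. Where it says the series, first, only, none or still open, it means among the compounds named here.

Going by the values given here, compound 1, with the structure `COc1ccc(-c2nc(CNc3ccc(C(=O)NO)cc3)n(-c3ccccc3)n2)cc1`, is one of two compounds measured in a functional assay on MGC-803 cells (Homo sapiens) for antiproliferative activity, read by MTT assay, with a stated time of 72 h; a higher number here means a weaker inhibitor, a lower number a stronger inhibitor. In this assay compound 1 gives only a limit, > 20000 nM, rather than a number. Its standing is therefore set by the limit of > 20000 nM in this assay, at which 1 of the 2 values shown sits, so it is known only to be a weak inhibitor. Compound 2, with the structure `O=C(NO)c1ccc(NCc2nc(-c3ccccc3)nn2-c2cccc(Cl)c2)cc1`, gives 13700 nM in this assay, also a weak value. Compound 3, with the structure `O=C(NO)c1ccc(NCc2nc(-c3cc4ccccc4s3)nn2-c2ccccc2)cc1`, has not yet been measured; it differs from compound 1 by 1-benzothiophen-2-yl in place of 4-methoxyphenyl on an aromatic carbon. Among the compounds with values here, with no measured step between these compounds, there is no guide to how large a change such a swap brings, and the expected movement in this assay is small, most likely within the usual scatter and perhaps slightly toward a stronger inhibitor. The expected step is an at least 1.3-fold lower number from compound 1 to compound 3 (0.12 log units; that floor lies within the scatter). For compound 3 the estimated value is 15000 nM, within a range from 4000 nM to 40000 nM.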

Compound 3, half-maximal inhibitory concentration: 6110 nM
Compound 3: middle estimate off by 2.5-fold (0.39 log units), on the high side, and the stated range covers the measured number.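

At this position, on an aromatic carbon of a five-membered aromatic ring with 3 nitrogen, the group carried does matter: in this assay, replacing 4-methoxyphenyl with 1-benzothiophen-2-yl gives an at least 3.2-fold lower number from compound 1 to compound 3 (0.51 log units; beyond the scatter). The entering group brings a five-membered aromatic ring with 1 hetero atom alongside a six-membered aromatic ring of carbon only, while the counts of hydrogen-bond donors and acceptors stay the same. Only a minimum can be given for this step, because compound 1 stands at a limit: the limit of > 20000 nM in this assay, at which 1 of the 3 values shown sits.

This single swap cannot separate the effect of adding the sulfur-containing ring from that of removing the methoxy group. It also leaves open whether a smaller thiophen-2-yl group or an all-carbon naphthyl group would serve equally well here.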